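This account rests on a few compounds, and the source may have more. Where it says the series, first, only, none or still open, it means among the compounds named here.

Working notes on the series. Compound 1, `NC(=O)c1ccc(Cn2cc(-c3ccc4cn[nH]c4c3)ccc2=O)cc1`, compound 2, `O=C(N1CCOCC1)n1cc(-c2ccc3cn[nH]c3c2)ccc1=O`, and compound 3, `O=c1ccc(-c2ccc3cc[nH]c3c2)cn1Cc1ccccc1`, have been run in an assay for inhibition of MAP kinase-interacting serine/threonine-protein kinase 1 (Homo sapiens), read by luminescence and ADP-Glo, with a stated time of 2 h; a higher number here means a weaker inhibitor, a lower number a stronger inhibitor. In this assay compound 1 gives only a limit, > 2000 nM. Compound 2 likewise gives only a limit, > 2000 nM. Compound 3 also returns a limit, > 2000 nM. So compound 2 stands with the other two at the limit of > 2000 nM in this assay, at which 3 of the 3 values shown sit, and no pair differing in one place offers a measured step.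

Compound 4, `O=c1ccc(-c2ccc3cn[nH]c3c2)cn1Cc1ccccc1F`, is next to be measured. It differs from compound 2 by 2-fluorobenzyl in place of (morpholin-4-yl)carbonyl on an aromatic nitrogen. Compound 3 also carries a benzyl group, on a different core, and sits at the limit.

Among the compounds with values here, with three limits and no measured step, the step that the limit leaves unreadable from compound 2 to compound 4 is expected to be none beyond the scatter. Compound 4 is estimated at 3000 nM, range 800 nM to 15000 nM, a limit being the likelier outcome.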

Compound 4, half-maximal inhibitory concentration: 47 nM
Beside the measured number, compound 4's estimate is 64-fold (1.81 log units) above it; measured number outside the range, below it.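

In this assay the substituent on the aromatic nitrogen can bring the series to a measurable value, with an at least 42-fold lower number from compound 2 to compound 4 (1.62 log units; beyond the scatter) on exchanging (morpholin-4-yl)carbonyl for 2-fluorobenzyl. A benzyl group alone does not settle it on this core: compound 1, with a different substituted benzyl group, gives > 2000 nM as a limit. Compound 4 is the only compound shown that gives a number rather than a limit: the limit of > 2000 nM in this assay, at which 3 of the 4 values shown sit.

Open, from the compounds shown here alone, is whether the fluorine is needed, which unsubstituted benzyl on this core would test. Also open, going by these compounds, is whether chlorine, a methoxy group or an amine in its place would hold the value.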